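The source may hold more compounds than are shown below. What is called first, only, known or untested is meant among the compounds shown, and "the series" means these compounds.

Measured in a functional assay on HL-60 cells (Homo sapiens) for antiproliferative activity, with a stated time of 72 h; a higher number here means a weaker inhibitor, a lower number a stronger inhibitor:
- compound 1 `Cc1cccc(CNc2ncnc3c2ncn3[C@@H]2O[C@H](CO)[C@@H](O)[C@H]2O)c1`: 6400 nM
- compound 2 `OC[C@H]1O[C@@H](n2cnc3c(NCc4ccc(Cl)c(Cl)c4)ncnc32)[C@H](O)[C@@H]1O`: 2000 nM

Of these two, compound 1 has the higher number and is the weaker inhibitor in this assay. Compound 3 `COc1cc(CNc2ncnc3c2ncn3[C@@H]2O[C@H](CO)[C@@H](O)[C@H]2O)cc(OC)c1` has not yet been measured. It differs from compound 1 as follows: 3,5-dimethoxyphenyl in place of 3-methylphenyl on a saturated chain carbon bound to a nitrogen on an aromatic ring. Going by the values given here, the one measured step at that same place, which brings in 3,4-dichlorophenyl, is a 3.2-fold lower number from compound 1 to compound 2 (0.51 log units; beyond the scatter). A single modest step is thin support, so a change of similar or smaller size towards a lower number is expected. The expected step is a 1.7-fold lower number from compound 1 to compound 3 (0.23 log units; within the scatter). For compound 3 the estimated value is 3800 nM, with an expected range of 1300 nM to 11000 nM.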

Compound 3, half-maximal inhibitory concentration: 20200 nM
Estimate against measurement, compound 3: 5.3-fold (0.73 log units) below; the measured number lies above the stated range.
By their numbers in this assay, from the lowest: compound 2; then compound 1; then compound 3.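

Going by these compounds alone, at this saturated chain carbon, the change of aryl group can also raise the number in this assay: 3,5-dimethoxyphenyl in place of 3-methylphenyl gives a 3.2-fold higher number from compound 1 to compound 3 (0.50 log units; beyond the scatter) and so runs opposite to the one earlier step at this place. Set against 3,4-dichlorophenyl, the same group gives a 10-fold higher number from compound 2 to compound 3 (1.00 log units; beyond the scatter) and the widest gap among these compounds. Nothing available here explains this order. Open, from the compounds shown here alone, is how a phenyl ring carrying a single methoxy, an amine or a carboxylic acid would read in this assay. Going by these compounds, a longer chain at this place also remains open.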